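The source may report more compounds than this note shows. Statements on the series, on what has been measured and on what is new or still open speak of the compounds shown alone.

Measured compounds:
Compound 1 `CC(=O)NC[C@H]1CN(c2ccc(OC[C@H](O)CNc3cccnc3)c(F)c2)C(=O)O1` gives -0.18 in a physicochemical assay for lipophilicity, read by HPLC; a higher number here means a more lipophilic compound, a lower number a more polar compound.
Compound 2 `CC(=O)NC[C@H]1CN(c2ccc(OC[C@@H]3CN(c4ccccc4)C(=O)O3)c(F)c2)C(=O)O1` gives 1.78 in this assay.

Compound 2 holds the higher of the two values; its nearest neighbour is compound 1, whose number lies lower by a gap beyond the scatter. Compound 3 `CC(=O)NC[C@H]1CN(c2ccc(OC[C@H]3CN(c4ccccc4)C(=O)O3)c(F)c2)C(=O)O1` keeps every atom and bond of compound 2 and differs only in configuration: the two compounds have the same atoms and bonds and differ only in configuration as drawn: 1 of 2 stereo elements differ; a stereocentre at a saturated ring carbon is drawn S in compound 2 and R in compound 3. Within the data shown here, no measured pair of this kind is available for comparison, so in this assay the expected step is no change at the digits printed from compound 2 to compound 3 (within the scatter), none beyond the scatter. Compound 3 is therefore estimated at 1.78, in the range 1.45 to 2.1.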

Compound 3, partition coefficient: 1.86
Estimate against measurement, compound 3: 0.08 log units below, within the range that was stated.
By their numbers in this assay, from the lowest: compound 1; then compounds 2 and 3 (each within the scatter of the next).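

Drawing the saturated ring carbon R instead of S gives, in this assay, a number 0.08 log units higher from compound 2 to compound 3 (within the scatter) and this is the first measured pair to isolate a single stereocentre. The earlier compounds shown here could not show this, as compounds 1 and 2 differ in more than one respect. Compounds 2 and 3 therefore cannot be told apart by this read-out, and the comparison is a clean one: the fact that compounds 2 and 3 differ only in the configuration as drawn.

As far as these compounds go, whether this stereocentre would matter as little with an amine or a carboxylic acid added to the shared core stays open. So does the effect of inverting the second stereocentre, which compounds 2 and 3 share.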